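The source may report more compounds than this note shows. Statements on the series, on what has been measured and on what is new or still open speak of the compounds shown alone.

Working notes on the series. Compound 1 `CCCCC(CC)C(=O)Nc1ccc2ccn(Cc3ccc(C(=O)NS(=O)(=O)c4ccccc4)cc3OC)c2c1` gives 8.6 in a functional assay (trachea) for antagonist activity, with Cavia porcellus as the target (on this read-out lower numbers stand for lower potency and higher numbers for higher potency (the scale is a negative logarithm)), and stands highest of the two numbers recorded there. Within the data shown here, compound 2 `CCCCC(CC)C(=O)Nc1ccc2ccn(Cc3ccc(C(=O)NS(=O)(=O)c4ccccc4)cc3)c2c1` gives 6.8 in this assay, and the step of a number 1.80 log units lower from compound 1 to compound 2 (beyond the scatter) is the only measured step in the set. Compound 3 `CCCCC(CC)C(=O)Nc1ccc2ccn(Cc3ccc(C(=O)NS(=O)(=O)c4ccc(F)cc4)cc3OC)c2c1` is not yet measured; it differs from compound 1 in one place: fluoro in place of hydrogen on an aromatic carbon. Among the measured compounds shown here, the one measured step concerns the methoxy on the benzyl ring and leaves the phenylsulfonyl part untouched, so it does not bear on the change from compound 1 to compound 3. For the measured compounds named here, no step in the set speaks to a substituent on the phenylsulfonyl ring. In the absence of any bearing data, the expected step in this assay is no change at the digits printed from compound 1 to compound 3 (within the scatter), none beyond the scatter in either direction. Compound 3 is therefore estimated at 8.6, with a range from 8 to 9.2.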

Compound 3, negative logarithm of the antagonist equilibrium constant: 7.7
Compound 3: middle estimate off by 0.90 log units, on the high side; the whole stated range lies above it.
By their numbers in this assay, from the lowest: compound 2; then compound 3; then compound 1.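

In this assay the phenylsulfonyl ring turns out not to be a silent place for substitution: fluoro in place of hydrogen, para to a large group, gives a clear drop (a number 0.90 log units lower from compound 1 to compound 3 (beyond the scatter)). Among these compounds, this is the first measured step at that ring, since the earlier step (a number 1.80 log units lower from compound 1 to compound 2 (beyond the scatter)) concerned the methoxy on the benzyl ring, so two separate parts of compound 1 now respond to a single change. No measurement at hand accounts for the drop seen with fluoro at this position.

The compounds shown leave open whether the drop is particular to fluoro or also follows from chloro, methyl or methoxy at the same place. They also leave open whether fluoro elsewhere on the phenylsulfonyl ring, or fluoro with hydrogen in place of the benzyl methoxy, behaves the same way.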